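Tolerance of HeLa Cells Toward Three Related Compounds

The source may hold more compounds than are shown below. What is called first, only, known or untested is meant among the compounds shown, and "the series" means these compounds.

Measured compounds:
Compound 1 `CC(=O)c1ccc(N2CCN(c3nc(=O)c4cc(C(F)(F)F)cc([N+](=O)[O-])c4s3)CC2)cc1` reaches only the assay limit in a toxicity assay on HeLa cells (Homo sapiens) for cytotoxicity, read by colorimetric assay, with a stated time of 72 h (a lower number here means that less compound is tolerated, a higher number that more compound is tolerated), namely > 105000 nM.
Compound 2 `N#Cc1ccccc1N1CCN(c2nc(=O)c3cc(C(F)(F)F)cc([N+](=O)[O-])c3s2)CC1` reaches only the assay limit in this assay, namely > 108000 nM.
Compound 3 `N#Cc1cccc(N2CCN(c3nc(=O)c4cc(C(F)(F)F)cc([N+](=O)[O-])c4s3)CC2)c1` reaches only the assay limit in this assay, namely > 108000 nM.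

Compound 3 therefore stands at a limit rather than at a number, and the two other compounds stand at limits as well: the limit of > 108000 nM in this assay, at which 2 of the 3 values shown sit, and (the limit of > 105000 nM in this assay, at which 1 of the 3 values shown sits). Every value is a limit. The steps between the measured compounds cannot be sized. The step that the two limits leave unreadable from compound 1 to compound 3 is unreadable, as are a step that the two limits leave unreadable from compound 2 to compound 3 and a step that the two limits leave unreadable from compound 1 to compound 2. What these three values show together is that exchanging the group on the ring amine nitrogen between a 4-acetylphenyl, a 2-cyanophenyl and a 3-cyanophenyl never brought the compounds into the range where this assay can read a number.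

Compound 4 `COc1cc(OC)cc(N2CCN(c3nc(=O)c4cc(C(F)(F)F)cc([N+](=O)[O-])c4s3)CC2)c1` carries the same core but differs from compound 3 in one place: 3,5-dimethoxyphenyl in place of 3-cyanophenyl on an amine nitrogen in a ring. Within the data shown here, no measured step bears directly on this exchange, and the three steps that exist are all unreadable. The expectation is therefore that compound 4 again sits at the limit, with no readable step that the limit leaves unreadable from compound 3 to compound 4. Compound 4 is estimated at 110000 nM, within 40000 nM to 300000 nM.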

Compound 4, half-maximal cytotoxic concentration: > 101000 nM
Compound 4 ended at the assay's limit; the forecaster's own chance of this, stated with the estimate: 85%; the middle value lies beyond the limit too.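

Compound 4 also gives only a limit in this assay: the limit of > 101000 nM in this assay, at which 1 of the 4 values shown sits. The steps to compound 4 from compound 1, compound 2 and compound 3 therefore cannot be read. The compounds shown leave open at what concentration any of them harms these cells, and whether exchanging the group on the ring amine nitrogen shifts that concentration at all.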